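Swapping the amino for a butyl on the shared core

This account rests on a few compounds, and the source may have more. Where it says the series, first, only, none or still open, it means among the compounds named here.

Measured so far:
- compound 1, `N=C(N)N/N=C/c1cccc(C(=N)N)c1`, gives 36 nM in an assay for inhibition of S-adenosylmethionine decarboxylase proenzyme (Rattus norvegicus); on this read-out lower numbers stand for stronger inhibition and higher numbers for weaker inhibition
- compound 2, `N=C(NN)N/N=C/c1cccc(C(=N)N)c1`, gives 210 nM in this assay

Compound 2 holds the highest of the two numbers shown, so it is the weaker inhibitor of the pair. Among the measured compounds shown here, its only neighbour is compound 1, and the step between them is the one measured change: a 5.8-fold higher number from compound 1 to compound 2 (0.77 log units; beyond the scatter).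

Compound 3, `CCCCNC(=N)N/N=C/c1cccc(C(=N)N)c1`, differs from compound 2 at the same nitrogen, this time (butyl in place of amino on an amine nitrogen). For the measured compounds named here, the single measured step, from hydrogen to amino, bears on it only indirectly: it shows that this nitrogen tolerates a change, but with a cost in this assay that went beyond the scatter. Going by the values given here, no measured compound carries an alkyl chain at this place, so the direction of the butyl swap cannot be read from the data; a modest step either way, or none beyond the scatter, is plausible.

On balance compound 3 is expected to give about 150 nM in this assay, within roughly 40 nM to 600 nM. That estimate means a step of a 1.4-fold lower number from compound 2 to compound 3 (0.15 log units; within the scatter), expected to stay close to compound 2.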

Compound 3, half-maximal inhibitory concentration: 160 nM
For compound 3 the middle estimate is 1.1-fold (0.03 log units) below the measured one, within the range that was stated.
By their numbers in this assay, from the lowest: compound 1; then compounds 3 and 2 (each within the scatter of the next).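

In this assay, replacing the amino with butyl gives a 1.3-fold lower number from compound 2 to compound 3 (0.12 log units; within the scatter), so two very different groups on this amine nitrogen perform alike: the amino has one heavy atom and the butyl has four carbons, yet the step stays within the scatter. The comparison with the hydrogen of compound 1 gives a 4.4-fold higher number from compound 1 to compound 3 (0.65 log units; beyond the scatter), so compound 1 remains the strongest inhibitor of the three, and both substituents shown on this nitrogen give a weaker result than hydrogen. Nothing available explains why the amino and butyl compounds match or why both fall short of compound 1.

A single amino and a single butyl cannot show whether the size of the group matters at this nitrogen, so the loss from hydrogen may or may not depend on which group is attached. A methyl or a longer chain such as octyl on the same nitrogen could show whether values stay close to those of compound 2 and compound 3 or move back towards that of compound 1.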